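Stilbene sulfonamides: swapping the para substituent

A few compounds are considered here, and "the series" means these few. Any claim that something is new, unique, unknown or untested is made for them only; others in the source may bear on it.

Compound 2 `NS(=O)(=O)c1ccc(/C=C/c2ccc(O)cc2)cc1` is one of two stilbene sulfonamides measured in a functional assay on K562 cells (Homo sapiens) for inhibition; a lower number here means a stronger inhibitor of growth, a higher number a weaker inhibitor of growth. Compound 2 gives 24900 nM, the higher of the two numbers, while compound 1 `NS(=O)(=O)c1ccc(/C=C/c2ccc(F)cc2)cc1` gives 14900 nM. Going by the values given here, the only step measured so far, a 1.7-fold higher number from compound 1 to compound 2 (0.22 log units; within the scatter), lies within the scatter, so the two compounds cannot be told apart on these data.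

Compound 3 `CN(C)c1ccc(/C=C/c2ccc(S(N)(=O)=O)cc2)cc1` is made from compound 2 by one change: dimethylamino in place of hydroxy on an aromatic carbon. This is the same position that was varied between compound 1 and compound 2, and that earlier swap moved the number only within the scatter. With nothing else to go on, the expectation is that the step of a 1.2-fold lower number from compound 2 to compound 3 (0.10 log units; within the scatter) will again be small, in neither direction beyond the scatter. Compound 3 is therefore estimated at 20000 nM, with a range from 7000 nM to 60000 nM.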

Compound 3, concentration for 50% growth inhibition: > 100000 nM
Compound 3: a limit, no number; the forecaster's own chance of this, stated with the estimate: 10%; middle value at least 5.0-fold (0.69 log units) from the limit.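

Unlike the swap from fluoro to hydroxy, this change shows that the group at this position can matter in this assay: dimethylamino in place of hydroxy gives an at least 4.0-fold higher number from compound 2 to compound 3 (0.60 log units; beyond the scatter), and dimethylamino in place of fluoro gives an at least 6.7-fold higher number from compound 1 to compound 3 (0.82 log units; beyond the scatter). Both steps are beyond the scatter, so compound 3 is a weaker inhibitor of growth than either compound 1 or compound 2. Compound 3 stands at a limit of the assay, not at a number: the limit of > 100000 nM in this assay, at which 1 of the 3 values shown sits.

From the compounds shown here alone, how much weaker compound 3 really is therefore stays open. Also open, going by these compounds, is whether a plain amine or a methoxy group at this position would stay close to compound 1 and compound 2 or behave more like dimethylamino.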